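This account rests on a few compounds, and the source may have more. Where it says the series, first, only, none or still open, it means among the compounds named here.

Of the compounds shown here, two built on a shared core have been tested in an assay on membranes from brain for binding affinity to adenosine receptor A1 (Rattus norvegicus), read by radioligand binding, tested at 20 uM; a lower number here means less inhibition, a higher number more inhibition at the concentration tested (going by the name of the read-out). Compound 1 `Cn1c(=O)[nH]c2c(cnn2-c2ccc(N)cc2)c1=N`, which carries the amino group, gives 0% in this assay. Compound 2 `Cn1c(=O)[nH]c2c(cnn2-c2ccc(Cl)cc2Cl)c1=N` gives 9% in this assay, and the two readings lie within the scatter of repeated measurements, so compound 1 cannot be set apart from compound 2 on these numbers. Compound 3 `Cn1c(=O)[nH]c2c(cnn2-c2ccccc2)c1=N` has not yet been measured. It differs from compound 1 by hydrogen in place of amino on an aromatic carbon. Among the measured compounds shown here, no step between two measured compounds is known here, and neither measured reading stands clearly above the scatter, so the expected step of a number 4 percentage points higher from compound 1 to compound 3 (within the scatter) in this assay is small, with no direction beyond the scatter. Compound 3 is therefore estimated at 4% in this assay, with a range from 0% to 18%.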

Compound 3, a percentage reported as inhibition, at one concentration (the size of the read-out at that concentration, not a potency): 30%
For compound 3 the middle estimate is 26 percentage points below the measured one; measured number outside the range, above it.
By their numbers in this assay, from the lowest: compounds 1 and 2 (each within the scatter of the next); then compound 3.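

Among the compounds shown here, the aromatic carbon para to a large group turns out to matter in this assay, where hydrogen in place of amino gives a number 30 percentage points higher from compound 1 to compound 3 (beyond the scatter), the only step here that lies beyond the scatter. The earlier compounds shown here could not show this, as they differ in more than one place and their readings could not be told apart. Nothing available accounts for the difference between amino and hydrogen at this position.

From the compounds shown here alone, it remains open whether amino is unusual here or whether other groups on this carbon, such as methoxy, hydroxyl or a carboxylic acid, would also read lower than hydrogen. Also open, going by these compounds, is how a single chloro group on this carbon would read against compound 3.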